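A few compounds are considered here, and "the series" means these few. Any claim that something is new, unique, unknown or untested is made for them only; others in the source may bear on it.

Measured compounds in the series:

compound 1, `CCNc1nc(-c2ccccc2)nc2c1nnn2Cc1ccccc1F`: 11000000 nM
compound 2, `OC1CCC(Nc2nc(-c3ccccc3)nc3c2nnn3Cc2ccccc2F)CC1`: 1850000 nM

Both numbers come from an assay on isolated protein for binding affinity to adenosine receptor A1 (Bos taurus); a lower number here means a stronger inhibitor, a higher number a weaker inhibitor. For the measured compounds named here, compound 2 stands at the lowest of the two values measured; its nearest neighbour is compound 1, and the one step between them, a 5.9-fold lower number from compound 1 to compound 2 (0.77 log units; beyond the scatter), is modest but beyond the scatter.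

The next compound, compound 3 with structure `CCCCNc1nc(-c2ccccc2)nc2c1nnn2Cc1ccccc1F`, differs from compound 2 in one place: butyl in place of 4-hydroxycyclohexyl on a nitrogen on an aromatic ring. Going by the values given here, only the step from compound 1 to compound 2 bears on this change, and only in part: it shows that exchanging a short chain on this nitrogen for the 4-hydroxycyclohexyl group gave the lower number, a 5.9-fold lower number from compound 1 to compound 2 (0.77 log units; beyond the scatter). Compound 3 goes back to a plain chain, though a longer one than in compound 1, so the number is expected to move back up toward that of compound 1 rather than fall further, and the step of a 2.7-fold higher number from compound 2 to compound 3 (0.43 log units; beyond the scatter) is the expected size of that reversal. The estimate for compound 3 in this assay is 5000000 nM, with a range from 1500000 nM to 15000000 nM.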

Compound 3, inhibition constant: 4300000 nM
Beside the measured number, compound 3's estimate is 1.2-fold (0.07 log units) above it; measured number inside the range.
By their numbers in this assay, from the lowest: compound 2; then compound 3; then compound 1.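

In this assay a plain chain on this nitrogen can also lower the number: going from ethyl to butyl gives (a 2.6-fold lower number from compound 1 to compound 3 (0.41 log units; beyond the scatter)), so the drop seen with the 4-hydroxycyclohexyl group (a 5.9-fold lower number from compound 1 to compound 2 (0.77 log units; beyond the scatter)) does not depend on having a ring or a hydroxyl at this position. The 4-hydroxycyclohexyl group still keeps the lower number against butyl (a 2.3-fold higher number from compound 2 to compound 3 (0.37 log units; beyond the scatter)), which places the three substituents in a single order from 4-hydroxycyclohexyl through butyl to ethyl, with each step beyond the scatter. No supporting measurement accounts for this order.

The change from 4-hydroxycyclohexyl to butyl alters the ring, the hydroxyl and the heavy-atom count together, so the compounds shown do not separate these contributions; a plain cyclohexyl on the same nitrogen would isolate the hydroxyl, and a hexyl chain would test whether lengthening continues to lower the number. Also open, going by these compounds, is whether any group at this position can take the number far from the level of compound 2 (1850000 nM), the lowest of the three.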